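A few compounds are considered here, and "the series" means these few. Any claim that something is new, unique, unknown or untested is made for them only; others in the source may bear on it.

Measured so far in a functional assay on HeLa cells (Homo sapiens) for cytotoxicity, read by MTT assay, with a stated time of 72 h; a lower number here means a stronger inhibitor, a higher number a weaker inhibitor:
Compound 1, `Cc1cc(C)n2nc(SCc3nnc(SCc4coc5ccccc5c4=O)n3N)nc2n1`: compound 1 gives only a limit, > 25000 nM.
Compound 2, `Cc1ccc2oc(CSc3nnc(N)s3)cc(=O)c2c1`: compound 2 gives only a limit, > 25000 nM.
Compound 3, `Cc1nnc(SCc2cc(=O)c3ccccc3o2)s1`: compound 3 gives only a limit, > 25000 nM.

Compound 2 stands at the limit of > 25000 nM in this assay, at which 3 of the 3 values shown sit, where every measured value of the series sits; the numbers do not separate it from compound 1 or compound 3. Compound 4, `Cc1ccc2oc(CSc3nnc(C)s3)cc(=O)c2c1`, differs from compound 2 by methyl in place of amino on an aromatic carbon. Going by the values given here, no measured step covers this change. Compound 3 carries the same 5-methyl-1,3,4-thiadiazol-2-yl group and also sits at the limit, so no step beyond the scatter is expected in this assay. Compound 4 is expected at 40000 nM, with a range of 20000 nM to 100000 nM, most likely reported again as a limit. The expected step is a step that the limit leaves unreadable from compound 2 to compound 4.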

Compound 4, half-maximal inhibitory concentration: > 25000 nM
Compound 4 was reported as a limit; the forecaster's own chance of this, stated with the estimate: 85%; the middle value does not contradict the limit.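

Compound 4 sits with compound 2 and compound 3 at the limit, so no step from either to compound 4 can be read: the limit of > 25000 nM in this assay, at which 4 of the 4 values shown sit.

Whether 5-amino-1,3,4-thiadiazol-2-yl and 5-methyl-1,3,4-thiadiazol-2-yl differ at all stays open: no compound shown gives a value that is more than a limit.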